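The compounds below may be only part of what the source reports. "The series", "measured", "known", "first", "only" and "open" are said of these compounds alone.

Of the compounds shown here, two have been tested in a functional assay on RPMI-8226 cells (Homo sapiens) for antiproliferative activity, read by sulforhodamine B assay, with a stated time of 48 h (a higher number here means a weaker inhibitor of growth, a lower number a stronger inhibitor of growth), so far. Compound 3 is compared with the second of them. Compound 1, `COc1ccc(OC)c(/C=C/c2nnc(Nc3ccc(Cl)cc3)o2)c1`, reaches only the assay limit there: its value is > 100000 nM, a limit and not a number. Within the data shown here, compound 2, `COc1ccc(OC)c(/C=C/C(=O)N/N=C/c2ccc(Cl)cc2)c1`, gives 300 nM in this assay, which is the only measured number in hand. The other result, that of compound 1, is a limit, as the limit of > 100000 nM in this assay, at which 1 of the 2 values shown sits, describes.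

Compound 3, `COc1ccc(OC)c(/C=C/C(=O)N/N=C/c2ccccc2)c1`, carries a single change relative to compound 2: hydrogen in place of chloro on an aromatic carbon, the group leaving from a position para to a large group. Among the measured compounds shown here, no measured pair in this set covers such a swap, so the size of the step has to be guessed from general experience. A small loss in this assay is expected for compound 3, though one that may not clear the scatter, with the step of a 2.0-fold higher number from compound 2 to compound 3 (0.30 log units; within the scatter) estimated from compound 2. Compound 3 is therefore estimated at 600 nM, within a range from 200 nM to 2500 nM.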

Compound 3, concentration for 50% growth inhibition: 2990 nM
Compound 3: middle estimate off by 5.0-fold (0.70 log units), on the low side, and the stated range ends below it.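

In this assay, among these compounds, replacing chloro with hydrogen on the aromatic carbon gives a 10-fold higher number from compound 2 to compound 3 (1.00 log units; beyond the scatter), the first single-place step and one that lies beyond the scatter. This shows that the position para to a large group is not indifferent: going from 4-chlorophenyl to phenyl, a change of one chlorine atom with the rest of the molecule untouched, is enough to produce a measurable loss in growth inhibition. The step itself gives the size of this effect, but nothing measured for these compounds accounts for it.

The compounds shown leave open whether chloro is special at this place or whether fluoro, bromo, methyl, methoxy or trifluoromethyl on the same aromatic carbon would hold the number of compound 2, match that of compound 3 or go beyond both. Compound 1 gives > 100000 nM in this assay, which is a limit and not a number, and it leaves open whether the same swap would matter at all on the core of compound 1.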